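Removing the second acetyl: what the lactone-side hydroxyl may do

The compounds below may be only part of what the source reports. "The series", "measured", "known", "first", "only" and "open" are said of these compounds alone.

Measured so far:
- compound 1 `C=C1CC[C@@H]2[C@](C)(CO[Si](C(C)C)(C(C)C)C(C)C)[C@H](OC(C)=O)CC[C@@]2(C)[C@@H]1C/C=C1/C(=O)OC[C@H]1OC(C)=O` — 1.41 uM
- compound 2 `C=C1CC[C@@H]2[C@](C)(CO[Si](C)(C)C(C)(C)C)[C@H](OC(C)=O)CC[C@@]2(C)[C@@H]1C/C=C1/C(=O)OC[C@H]1OC(C)=O` — 0.34 uM
- compound 3 `C=C1CC[C@@H]2[C@](C)(CO[Si](C)(C)C(C)(C)C)[C@H](O)CC[C@@]2(C)[C@@H]1C/C=C1/C(=O)OC[C@H]1OC(C)=O` — 1.03 uM

All three share one core and were tested in a functional assay on P388 cells (Mus musculus) for cytotoxicity, read by sulforhodamine B assay; a higher number here means that more compound is needed for the effect, a lower number that less compound is needed. Compound 3 holds the second highest number of the three: its number sits close to that of compound 1, within the usual scatter, while it stands clearly above that of compound 2, as the step of a 3.0-fold higher number from compound 2 to compound 3 (0.48 log units; beyond the scatter) shows. That step is the one that matters here, since it is the same kind of change as the one now being made. Compound 4 `C=C1CC[C@@H]2[C@](C)(CO[Si](C)(C)C(C)(C)C)[C@H](O)CC[C@@]2(C)[C@@H]1C/C=C1/C(=O)OC[C@H]1O` differs from compound 3 by hydrogen in place of acetyl on an oxygen on a saturated carbon, that is, acetoxy to hydroxy on the second of the two acetylated oxygens. The earlier removal of an acetyl from compound 2 to compound 3 raised the number by a modest amount beyond the scatter, so a rise of a similar size is expected here. Compound 4 is therefore expected to give about 2.5 uM in this assay, within a range from 0.9 uM to 7 uM, an expected step of a 2.4-fold higher number from compound 3 to compound 4 (0.39 log units; beyond the scatter) from compound 3.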

Compound 4, concentration for half-maximal effect: 8.39 uM
Compound 4: the middle estimate sits 3.4-fold (0.53 log units) below what was measured; the whole stated range lies below it.
By their numbers in this assay, from the lowest: compound 2; then compounds 3 and 1 (each within the scatter of the next); then compound 4.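

Removing the acetyl from this second oxygen, on a saturated carbon whose other neighbour is a saturated ring carbon, has a larger effect than the earlier removal: in this assay the change gives an 8.1-fold higher number from compound 3 to compound 4 (0.91 log units; beyond the scatter) while the same swap at the other acetylated oxygen gives a 3.0-fold higher number from compound 2 to compound 3 (0.48 log units; beyond the scatter) by comparison. Acetoxy to hydroxy is therefore not a change of one fixed size on this core, and the two acetylated oxygens do not count equally. With the silyl group of compound 3 in place, keeping the acetoxy here goes with a clearly lower number.

On these data alone, whether this holds with the silyl group of compound 1, or whether a benzoyl ester or a methyl ether on this oxygen would match the acetoxy, remains open. Nothing available explains the difference between the two steps.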